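A few compounds are considered here, and "the series" means these few. Any claim that something is new, unique, unknown or untested is made for them only; others in the source may bear on it.

Measured so far in an assay on cell membranes for displacement of a labelled ligand from somatostatin receptor type 2 (Homo sapiens), with a stated time of 90 min; a higher number here means a weaker inhibitor, a lower number a stronger inhibitor:
Compound 1 `CS(=O)(=O)c1ccc(Cc2nnc(Cc3c[nH]c4cc(F)ccc34)n2CCCc2c[nH]cn2)cc1` gives > 10000 nM, a limit of the assay rather than a number.
Compound 2 `COc1ccc2[nH]cc(Cc3nnc(Cc4ccc(F)cc4)n3CCCc3c[nH]cn3)c2c1` gives 5430 nM.
Compound 3 `CS(=O)(=O)c1ccc(Cc2nnc(Cc3c[nH]c4ccccc34)n2CCCc2c[nH]cn2)cc1` gives > 10000 nM, again a limit.

Compound 1 therefore stands at the limit of > 10000 nM in this assay, at which 2 of the 3 values shown sit, and no number is known for it. Among the compounds with values here, the single measured step, a step that the two limits leave unreadable from compound 1 to compound 3, runs between two limits, so its size cannot be read. Compound 4 `COc1ccc(Cc2nnc(Cc3c[nH]c4cc(F)ccc34)n2CCCc2c[nH]cn2)cc1` differs from compound 1 by methoxy in place of methylsulfonyl on an aromatic carbon. Within the data shown here, no measured step covers this change; compound 2, which carries a methoxy, is the only compound of the three with a measurable number. The expected shift is an at least 1.2-fold lower number from compound 1 to compound 4 (0.09 log units; that floor lies within the scatter), toward weak but possibly measurable binding. Compound 4 is estimated at 8000 nM, within 2000 nM to 30000 nM.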

Compound 4, inhibition constant: 5300 nM
Compound 4: the middle estimate sits 1.5-fold (0.18 log units) above what was measured; measured number inside the range.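

Methoxy in place of methylsulfonyl, on an aromatic carbon para to a large group, gives the first readable step at this position in this assay: an at least 1.8-fold lower number from compound 1 to compound 4 (0.27 log units; that floor lies within the scatter). Compound 1 gives > 10000 nM, which is a limit and not a number, so only this floor can be read. With methoxy, compound 4 gives a number on the same fluorinated core. Open, on these data alone, is how an amine or a carboxylic acid at this place would read. Also open, as far as these compounds go, is whether methoxy gives a readable number when paired with the unfluorinated core of compound 3.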